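A few compounds are considered here, and "the series" means these few. Any claim that something is new, unique, unknown or untested is made for them only; others in the source may bear on it.

Compound 3 `N=C(NCCO)N1C[C@H](O)[C@@H](O)[C@H](O)[C@H]1CO` is where this comparison begins. In an assay for inhibition of beta-galactosidase (Bos taurus), read by spectrophotometry, with a stated time of 30 min (a lower number here means a stronger inhibitor, a higher number a weaker inhibitor), compound 3 reaches only the limit of > 1000000 nM, which is a limit of the measurement and not a number. Two related compounds do have numbers: compound 1 `CCCCNC(=N)N1C[C@H](O)[C@@H](O)[C@H](O)[C@H]1CO` gives 15000 nM in this assay, and compound 2 `CCCCCCCCNC(=N)N1C[C@H](O)[C@@H](O)[C@H](O)[C@H]1CO` gives 2600 nM in this assay. The step of a 5.8-fold lower number from compound 1 to compound 2 (0.76 log units; beyond the scatter) came with butyl in place of hydrogen on a saturated chain carbon, four bonds along the chain from an amine nitrogen. Moving towards compound 3, the step of an at least 66-fold higher number from compound 1 to compound 3 (1.82 log units; beyond the scatter) and the step of an at least 380-fold higher number from compound 2 to compound 3 (2.58 log units; beyond the scatter) both went far towards weaker inhibition, ending at the limit of > 1000000 nM in this assay, at which 1 of the 3 values shown sits.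

Compound 4 `N=C(NCCCc1ccccc1)N1C[C@H](O)[C@@H](O)[C@H](O)[C@H]1CO` differs from compound 3 by benzyl in place of hydroxy on a saturated chain carbon, two bonds along the chain from an amine nitrogen. This change removes the hydroxy whose arrival made the large steps to compound 3, and puts a longer carbon chain in its place, as the chains of compound 1 and compound 2 are. A large step towards a lower number is therefore expected in this assay. Compound 4 is expected to give about 6000 nM, in a range from 1000 nM to 40000 nM. This estimate means an expected step of an at least 160-fold lower number from compound 3 to compound 4 (2.22 log units; beyond the scatter).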

Compound 4, half-maximal inhibitory concentration: 6200 nM
Compound 4: the middle estimate sits 1.0-fold (0.01 log units) below what was measured; measured number inside the range.
By their numbers in this assay, from the lowest: compound 2; then compound 4; then compound 1. At a limit, above all of these: compound 3.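

Hydroxy at this place is not the only alternative to a plain alkyl chain: a chain ending in an aromatic ring also gives a measurable number in this assay, with an at least 160-fold lower number from compound 3 to compound 4 (2.20 log units; beyond the scatter). Compound 3 itself stands only at a limit and not at a number: the limit of > 1000000 nM in this assay, at which 1 of the 4 values shown sits. Compound 4 falls among the two alkyl compounds, with a 2.4-fold lower number from compound 1 to compound 4 (0.38 log units; beyond the scatter) and a 2.4-fold higher number from compound 2 to compound 4 (0.38 log units; beyond the scatter), so a phenyl at the end of the chain is tolerated about as well as a plain carbon chain.

Going by these compounds, it remains open whether the phenyl ring adds anything that a saturated chain of similar size would not. An amine or a carboxylic acid at the chain end, or a hydroxy on a longer chain, would show whether the loss at compound 3 follows the hydroxy itself or its short chain.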